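Diphenylmethylpiperidine series: carboxylic acid replaced by acetamide

A few compounds are considered here, and "the series" means these few. Any claim that something is new, unique, unknown or untested is made for them only; others in the source may bear on it.

Measured so far:
compound 1, `COc1cc(C(C)=O)ccc1OCCCN1CCC(=C(c2ccc(F)cc2)c2ccc(F)cc2)CC1`: 3.98 nM
compound 2, `COc1cc(C(=O)O)ccc1OCCCN1CCC(C(c2ccc(F)cc2)c2ccc(F)cc2)CC1`: 79.4 nM

In a functional assay (aorta) with Oryctolagus cuniculus as the target (on this read-out lower numbers stand for tighter binding and higher numbers for weaker binding), compound 2 gives 79.4 nM, the higher of the two numbers; compound 1 gives 3.98 nM, a gap beyond the scatter. Compound 3, `CC(=O)Nc1ccc(OCCCN2CCC(C(c3ccc(F)cc3)c3ccc(F)cc3)CC2)cc1`, is not yet measured. The change is 4-acetamidophenyl in place of 4-carboxy-2-methoxyphenyl on an oxygen on a saturated carbon.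

Among the measured compounds shown here, no step between measured compounds covers this change, so the direction rests on the two values alone. Compound 2 carries a carboxylic acid and stands highest; replacing it is expected to move the number down, beyond the scatter, the expected step being a 6.6-fold lower number from compound 2 to compound 3 (0.82 log units; beyond the scatter). Compound 3 is estimated at 12 nM, within 3 nM to 50 nM.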

Compound 3, dissociation constant: 12.6 nM
Compound 3: the middle estimate sits 1.1-fold (0.02 log units) below what was measured, and the stated range covers the measured number.
By their numbers in this assay, from the lowest: compound 1; then compound 3; then compound 2.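

On the oxygen on a saturated carbon, the aryl group need not carry a carboxylic acid: 4-acetamidophenyl in place of 4-carboxy-2-methoxyphenyl gives a 6.3-fold lower number from compound 2 to compound 3 (0.80 log units; beyond the scatter) in this assay. The carboxylic acid and the methoxy group leave together, so the step cannot be assigned to either alone. No evidence at hand bears on this step. Still open, going by these compounds, is how a 4-carboxyphenyl group or an acetamide ring that keeps the methoxy group would read, and whether a primary amide or a nitrile would read like the acetamide.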